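The source may report more compounds than this note shows. Statements on the series, on what has been measured and on what is new or still open speak of the compounds shown alone.

Working notes on the series. Compound 1 `COc1ccccc1C(=O)NC(=O)Nc1ccc(N2CCCCC2)c(Cl)c1`, compound 2 `COc1ccccc1C(=O)NC(=S)Nc1ccc(N2CCCCC2)c(Cl)c1` and compound 3 `COc1ccccc1C(=O)NC(=O)Nc1ccc(-c2nccs2)c(C(F)(F)F)c1` carry the same shared core and differ in the urea or thiourea link and in the substituted aniline half.

In an ADME assay on LLC-PK1 cells (Sus scrofa) for permeability (on this read-out lower numbers stand for lower permeability and higher numbers for higher permeability), compound 1 gives < 1 10^-6 cm/s, which is a limit of the assay and not a number (the limit of < 1 10^-6 cm/s in this assay, at which 1 of the 3 values shown sits). In this assay compound 2 gives 1.8 10^-6 cm/s. Compound 3 gives 12 10^-6 cm/s in this assay, the highest of the two numbers shown; the nearest number, that of compound 2, lies well beyond the scatter. Going by the values given here, no two of these three compounds differ in only one place, so no single step between measured compounds is known.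

Compound 4 `COc1ccccc1C(=O)NC(=O)Nc1ccc(-c2ccccc2)c(C(F)(F)F)c1` is not yet measured. It differs from compound 3 in one place: phenyl in place of 1,3-thiazol-2-yl on an aromatic carbon. With phenyl in place of 1,3-thiazol-2-yl on an aromatic carbon and the rest unchanged, the expected step of a 1.3-fold higher number from compound 3 to compound 4 (0.10 log units; within the scatter) in this assay is small, at most a slight move upward, and expected to stay within the scatter. Compound 4 is accordingly estimated at 15 10^-6 cm/s in this assay, with a range from 7 10^-6 cm/s to 30 10^-6 cm/s. A low reading is not expected for compound 4 because compound 3 gives 12 10^-6 cm/s.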

Compound 4, apparent permeability: < 1 10^-6 cm/s
Compound 4 gave a limit, no number (the forecaster's own chance of this, stated with the estimate: 5%); middle value at least 15-fold (1.17 log units) from the limit.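

At this position, on an aromatic carbon ortho to a trifluoromethyl group and para to a large group, phenyl in place of 1,3-thiazol-2-yl gives an at least 12-fold lower number from compound 3 to compound 4 (1.07 log units; beyond the scatter) in this assay. Going by these compounds alone, this is the first step that changes only one place, and it shows that this place alone can decide the read-out: exchanging a five-membered aromatic ring with 2 hetero atoms for a six-membered aromatic ring of carbon only is not a neutral swap here, and the result for compound 3 does not carry over to compound 4. The value of compound 4 is a limit of the assay and not a number, so the step has a lower bound but no full size: the limit of < 1 10^-6 cm/s in this assay, at which 2 of the 4 values shown sit.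

As far as these compounds go, it stays open whether the ring nitrogen, the ring sulfur or the ring size matters most, and a pyridin-2-yl, thiophen-2-yl or 1,3-oxazol-2-yl group at this position would separate these. Also open, from the compounds shown here alone, is whether the same exchange gives a step of this size with a chloro group in place of the trifluoromethyl group.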